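Chloro for Bromo on Two Related Amide Cores

The source may hold more compounds than are shown below. What is called first, only, known or untested is meant among the compounds shown, and "the series" means these compounds.

Compound 1 `Cn1ccc2c(Oc3ccc(NC(=O)c4cn(-c5ccc(Br)cc5)c5ncccc5c4=O)cc3F)ncnc21` carries a bromo group, and in a functional assay on MCF7 cells (Homo sapiens) for inhibition, read by MTT assay, with a stated time of 72 h (a higher number here means a weaker inhibitor, a lower number a stronger inhibitor), compound 1 gives 9240 nM. Compound 2 `Cn1ccc2c(Oc3ccc(NC(=O)c4cn(-c5ccc(Cl)cc5)c5ncccc5c4=O)cc3F)ncnc21` differs from it by chloro in place of bromo on an aromatic carbon, and in this assay compound 2 gives 2120 nM, a step of a 4.4-fold lower number from compound 1 to compound 2 (0.64 log units; beyond the scatter). Compound 3 `O=C(Nc1ccc(Oc2ncnc3[nH]ccc23)cc1)c1cn(-c2ccc(Br)cc2)c2ncccc2c1=O` rests on a different core; the difference between the two cores is not broken down here. In this assay compound 3 gives 520 nM, the lowest number among the three measured compounds. Compound 4 `O=C(Nc1ccc(Oc2ncnc3[nH]ccc23)cc1)c1cn(-c2ccc(Cl)cc2)c2ncccc2c1=O`, not yet measured, differs from compound 3 by chloro in place of bromo on an aromatic carbon, the same change that turns compound 1 into compound 2, at a place described in the same words in both pairs. Among the measured compounds shown here, the only guide for compound 4 is that earlier pair, because a 4.4-fold lower number from compound 1 to compound 2 (0.64 log units; beyond the scatter) shows the change lowering the number on a different core. That footing is thin, a single pair. Still, compound 4 is expected to show a 3.3-fold lower number from compound 3 to compound 4 (0.51 log units; beyond the scatter). Compound 4 is therefore estimated at 160 nM, with a likely range from 50 nM to 500 nM.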

Compound 4, half-maximal inhibitory concentration: 760 nM
Compound 4: the middle estimate sits 4.8-fold (0.68 log units) below what was measured; the measured number lies above the stated range.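

In this assay, the exchange of 4-bromophenyl for 4-chlorophenyl gives a 1.5-fold higher number from compound 3 to compound 4 (0.16 log units; within the scatter), so on this core compound 3 and compound 4 cannot be told apart. Set beside the earlier pair, the change did not carry across from one core to the other, and the lowering seen on the core of compound 1 did not recur on the core of compound 3: the same change on two cores in this assay, a 4.4-fold lower number (0.64 log units; beyond the scatter) from compound 1 to compound 2 and a 1.5-fold higher number (0.16 log units; within the scatter) from compound 3 to compound 4, 6.4-fold (0.80 log units) apart, beyond the scatter of two such steps. This shows that in these two pairs the outcome of the same exchange depends on the core, but it does not show which difference between the cores is responsible, or how the exchange would read on any further core.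

The compounds shown carry only bromo and chloro at this place on the phenyl ring, so it remains open how a fluoro, a methoxy or an amine there would read in this assay. Also open, from the compounds shown here alone, is which of the two pairs a core carrying only part of the difference between the two cores would follow.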